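The source may hold more compounds than are shown below. What is called first, only, known or untested is meant among the compounds shown, and "the series" means these compounds.

Working notes on the series. Compound 1 `Oc1ccc(-c2cc(-c3cccs3)cc(-c3cccc(O)c3)n2)cc1` gives 4140 nM in a functional assay on HeLa cells (Homo sapiens) for cytotoxicity, read by CCK-8 assay; a higher number here means a weaker inhibitor, a lower number a stronger inhibitor. Compound 3 `Oc1cccc(-c2cc(-c3ccccn3)cc(-c3cccc(O)c3)n2)c1` gives 6500 nM in this assay, and the gap between compound 3 and compound 1 lies within the scatter, so the two cannot be separated. Compound 2 `Oc1ccc(-c2cc(-c3ccccn3)cc(-c3ccccc3O)n2)cc1` shows only a limit in this assay, > 50000 nM; that much is given by the limit of > 50000 nM in this assay, at which 1 of the 3 values shown sits, and no number stands for it. Compound 4 `Oc1ccc(-c2cc(-c3ccccn3)cc(-c3cccc(O)c3)n2)cc1` is not yet measured; it differs from compound 3 by 4-hydroxyphenyl in place of 3-hydroxyphenyl on an aromatic carbon. Among the measured compounds shown here, no step between measured compounds covers this exchange, so the expectation rests on compound 1 and compound 3 alone. The expected step of a 1.3-fold lower number from compound 3 to compound 4 (0.11 log units; within the scatter) is judged to stay within the scatter, with compound 4 estimated at 5000 nM, between 2000 nM and 15000 nM.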

Compound 4, half-maximal inhibitory concentration: 1930 nM
Compound 4: middle estimate off by 2.6-fold (0.41 log units), on the high side; the measured number lies below the stated range.
By their numbers in this assay, from the lowest: compound 4; then compounds 1 and 3 (each within the scatter of the next). At a limit, above all of these: compound 2.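

On the aromatic carbon next to the ring nitrogen, the placing of the hydroxy group on the phenyl ring now shows up in this assay: 4-hydroxyphenyl in place of 3-hydroxyphenyl gives a 3.4-fold lower number from compound 3 to compound 4 (0.53 log units; beyond the scatter), and 3-hydroxyphenyl in place of 2-hydroxyphenyl gives an at least 25-fold lower number from compound 2 to compound 4 (1.41 log units; beyond the scatter). The value of compound 2 is a limit and not a number, so that second step has no fixed size: the limit of > 50000 nM in this assay, at which 1 of the 4 values shown sits A second place also counts, with pyridin-2-yl in place of thiophen-2-yl giving a 2.1-fold lower number from compound 1 to compound 4 (0.33 log units; beyond the scatter). Open, going by these compounds, is whether a methoxy group or an amine in place of the hydroxy group on the 4-hydroxyphenyl ring would keep the lower number.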